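The source may hold more compounds than are shown below. What is called first, only, known or untested is meant among the compounds shown, and "the series" means these compounds.

Working notes on a small series sharing one core, read in a functional assay on DU-145 cells (Homo sapiens) for cytotoxicity, read by MTT assay, with a stated time of 48 h; a higher number here means a weaker inhibitor, a lower number a stronger inhibitor. Compound 1 `C=C1CCC[C@]2(C)CCC(c3cn(-c4ccc(OC)cc4)nn3)=CC[C@@]12C` gives 58900 nM, compound 2 `C=C1CCC[C@]2(C)CCC(c3cn(-c4ccc(I)cc4)nn3)=CC[C@@]12C` gives 145000 nM and compound 3 `C=C1CCC[C@]2(C)CCC(c3cn(CC(=O)Nc4ccc(C)cc4)nn3)=CC[C@@]12C` gives 254000 nM. Compound 3 thus stands at a higher number than compound 1, while its value lies within the scatter of that of compound 2.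

Compound 4 `C=C1CCC[C@]2(C)CCC(c3cn(CC(=O)Nc4ccccc4)nn3)=CC[C@@]12C` is not yet measured and differs from compound 3 by one change: hydrogen in place of methyl on an aromatic carbon, para to a large group. Within the data shown here, the single measured one-place step is a 2.5-fold higher number from compound 1 to compound 2 (0.39 log units; beyond the scatter), with iodo in place of methoxy on an aromatic carbon. That step is modest and involves neither methyl nor hydrogen, so it bears only loosely on this change. It gives no reason to expect more than a small shift, and no direction is supported. The estimated step is a 1.2-fold lower number from compound 3 to compound 4 (0.06 log units; within the scatter), which is expected to stay within the scatter. For compound 4 the expected value is 220000 nM, with an estimated range of 105000 nM to 450000 nM.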

Compound 4, half-maximal inhibitory concentration: 146000 nM
Compound 4: the middle estimate sits 1.5-fold (0.18 log units) above what was measured; measured number inside the range.
By their numbers in this assay, from the lowest: compound 1; then compounds 2, 4 and 3 (each within the scatter of the next).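

In this assay, hydrogen in place of methyl on this aromatic carbon, para to a large group, gives a 1.7-fold lower number from compound 3 to compound 4 (0.24 log units; within the scatter), so compound 3 and compound 4 cannot be told apart. Among these compounds, this is the first one-place step read on the phenylcarbamoyl side chain, and it shows that the methyl at this position is not required for the reading seen with compound 3. Nothing measured here bears on why this position responds as it does.

With only methyl and hydrogen shown at this carbon, it remains open whether an amine or a carboxylic acid there would shift the number beyond the scatter. Going by these compounds, the step also rests on a single pair, so whether the same change would read alike on another aryl group remains open.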